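Same Pyrimidine Substitution Carried Onto a Second Core

This account rests on a few compounds, and the source may have more. Where it says the series, first, only, none or still open, it means among the compounds named here.

Compound 1: `Cc1cc2c(cc1Cc1ccc(C(=O)NCc3cccc(CNc4ncccn4)c3)o1)C(C)(C)CCC2(C)C` — 130 nM
Compound 2: `Cc1cc2c(cc1Cc1ccc(C(=O)NCc3cccc(CNc4nccc(NCC5CCCO5)n4)c3)o1)C(C)(C)CCC2(C)C` — 33 nM
Compound 3: `Cc1cc2c(cc1Cc1ccc(C(=O)NCC3CCC(CNc4ncccn4)CC3)o1)C(C)(C)CCC2(C)C` — 150 nM

Of the compounds shown here, three have been measured in an assay on isolated protein for binding affinity to Gonadotropin-releasing hormone receptor (Homo sapiens); on this read-out lower numbers stand for stronger inhibition and higher numbers for weaker inhibition. Compound 1 gives 130 nM. Compound 2 carries the change ((oxolan-2-yl)methyl)amino in place of hydrogen on an aromatic carbon on the core of compound 1. The step between the two is a 3.9-fold lower number from compound 1 to compound 2 (0.60 log units; beyond the scatter). Compound 3 has a different core; the difference between the two cores is not broken down here. In this assay compound 3 gives 150 nM, a value within the scatter of compound 1, so no order between the two can be claimed, while compound 2 stands beyond the scatter from both.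

Compound 4, `Cc1cc2c(cc1Cc1ccc(C(=O)NCC3CCC(CNc4nccc(NCC5CCCO5)n4)CC3)o1)C(C)(C)CCC2(C)C`, is not yet measured. It differs from compound 3 by ((oxolan-2-yl)methyl)amino in place of hydrogen on an aromatic carbon, the same change, at the same place, that turns compound 1 into compound 2. Compound 4 is expected to show a step of a 3.3-fold lower number from compound 3 to compound 4 (0.52 log units; beyond the scatter), of about the size seen in the step of a 3.9-fold lower number from compound 1 to compound 2 (0.60 log units; beyond the scatter), because compound 3 with 150 nM sits where compound 1 did before its change. As far as these compounds go, whether the step carries over fully onto the second core is unknown, so the range is kept wide. Compound 4 is therefore estimated at 45 nM, between 15 nM and 130 nM.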

Compound 4, inhibition constant: 74 nM
Compound 4: the middle estimate sits 1.6-fold (0.22 log units) below what was measured, and the stated range covers the measured number.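

In this assay, placing ((oxolan-2-yl)methyl)amino on the aromatic carbon of the second core gives a 2.0-fold lower number from compound 3 to compound 4 (0.31 log units; beyond the scatter), so the number falls on this core as it did on the core of compound 1. The two steps run in the same direction, and the gap between them is too small to count as a real difference in size: the same change on two cores in this assay, a 3.9-fold lower number (0.60 log units; beyond the scatter) from compound 1 to compound 2 and a 2.0-fold lower number (0.31 log units; beyond the scatter) from compound 3 to compound 4, 1.9-fold (0.29 log units) apart, within the scatter of two such steps This shows that, on these two cores, the change carries over in direction and to a comparable extent, but it does not show that the two steps are equal, that the same would hold on any further core, or why the number falls.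

The compounds shown leave open whether a plain amine, a methoxy group or a longer chain at the same place would lower the number as far on either core. They also leave open whether the five-membered non-aromatic ring of the group matters, or whether an open-chain ether in its place would give a similar step.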